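A few compounds are considered here, and "the series" means these few. Any claim that something is new, unique, unknown or untested is made for them only; others in the source may bear on it.

Compound 1 `Cc1ccc(C(=O)NC(=O)c2ccccc2O)cc1`: 46 ug/mL
Compound 2 `CS(=O)(=O)c1ccc(C(=O)NC(=O)c2ccccc2O)cc1`: > 100 ug/mL
Compound 3 `O=C(NC(=O)c1ccccc1O)c1ccc([N+](=O)[O-])cc1`: not yet measured

In an ADME assay on L6 cells (Rattus norvegicus) for cytotoxicity, read by resazurin assay, with a stated time of 72 h (on this read-out lower numbers stand for stronger inhibition and higher numbers for weaker inhibition), compound 2 reads > 100 ug/mL, which is a limit of the assay and not a number. Compound 3 carries nitro in place of methylsulfonyl on an aromatic carbon. Within the data shown here, no measured step involves nitro, so the only guide is an at least 2.1-fold higher number from compound 1 to compound 2 (0.33 log units; beyond the scatter), which lies beyond the scatter. With that single step as the basis, a modest move to a lower number is expected, estimated as an at least 1.6-fold lower number from compound 2 to compound 3 (0.22 log units; that floor lies within the scatter). The expected value for compound 3 is 60 ug/mL, with an estimated range of 20 ug/mL to 100 ug/mL.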

Compound 3, half-maximal inhibitory concentration: 53 ug/mL
The estimate for compound 3 lay 1.1-fold (0.05 log units) above the measured number, within the range that was stated.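

In this assay, nitro in place of methyl gives a 1.2-fold higher number from compound 1 to compound 3 (0.06 log units; within the scatter), so these two groups on this aromatic carbon read alike. Nitro in place of methylsulfonyl gives an at least 1.8-fold lower number from compound 2 to compound 3 (0.27 log units; that floor lies within the scatter), so methylsulfonyl may stand apart from both, although the floor of this step does not clear the scatter. The reading for compound 2 remains a limit of the assay and not a number: the limit of > 100 ug/mL in this assay, at which 1 of the 3 values shown sits.

On these data alone, how far methylsulfonyl really stands apart therefore remains open. So does how an amine, a carboxylic acid or a longer chain on this aromatic carbon would read in this assay.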